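This account rests on a few compounds, and the source may have more. Where it says the series, first, only, none or still open, it means among the compounds named here.

Of the compounds shown here, three of a shared core have been measured so far. Compound 1 `C#CCCOC(=O)c1ccc(C(CC)(CC)c2ccc(OCCC(O)(CC)CC)c(C)c2)n1CC` gives 6030 nM in an assay on cells for agonist activity at vitamin D3 receptor (Homo sapiens), with a stated time of 96 h (on this read-out lower numbers stand for an effect already at smaller amounts and higher numbers for an effect only at larger amounts of compound), compound 2 `CCn1c(C(=O)Nc2cccc(C(F)(F)F)c2)ccc1C(CC)(CC)c1ccc(OCCC(O)(CC)CC)c(C)c1` gives 5900 nM, and compound 3 `CCOC(=O)CN(C)C(=O)c1ccc(C(CC)(CC)c2ccc(OCCC(O)(CC)CC)c(C)c2)n1CC` gives 520 nM. Compound 2 therefore stands second highest of the three: its number and that of compound 1 lie within the scatter of each other, as a 1.0-fold lower number from compound 1 to compound 2 (0.01 log units; within the scatter) shows, while compound 3 stands far lower, with an 11-fold lower number from compound 2 to compound 3 (1.05 log units; beyond the scatter).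

Compound 4 `CCn1c(C(=O)NC(CO)CCO)ccc1C(CC)(CC)c1ccc(OCCC(O)(CC)CC)c(C)c1` is not yet measured. It differs from compound 2 in one place: 3-hydroxy-1-(hydroxymethyl)propyl in place of 3-(trifluoromethyl)phenyl on an amide-type nitrogen.

Among the compounds with values here, two measured steps bear on this change. The exchange of the same 3-(trifluoromethyl)phenyl amino group for a ((ethoxycarbonyl)methyl)(methyl)amino group, from compound 2 to compound 3, gave a large drop in number, whereas the exchange between ester and aryl amide, from compound 1 to compound 2, changed nothing beyond the scatter. Within the data shown here, a second departure from the aryl amide is thus expected to move the number downward, though the direction of such a swap has only one precedent. A modest step is estimated, a 3.0-fold lower number from compound 2 to compound 4 (0.47 log units; beyond the scatter). Compound 4 is therefore expected to give about 2000 nM, within a range from 500 nM to 8000 nM.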

Compound 4, half-maximal effective concentration: 2490 nM
For compound 4 the middle estimate is 1.2-fold (0.10 log units) below the measured one; measured number inside the range.
By their numbers in this assay, from the lowest: compound 3; then compound 4; then compounds 2 and 1 (each within the scatter of the next).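

At the amide-type nitrogen, an aromatic ring proves unnecessary for a lower number in this assay (a 2.4-fold lower number from compound 2 to compound 4 (0.37 log units; beyond the scatter)), as the ring-free 3-hydroxy-1-(hydroxymethyl)propyl group replaces 3-(trifluoromethyl)phenyl. The amide bearing this group also gives a lower number than the but-3-ynyl ester (a 2.4-fold lower number from compound 1 to compound 4 (0.38 log units; beyond the scatter)), so this ring-free amide separates from the ester where the aryl amide did not. It does not match the ((ethoxycarbonyl)methyl)(methyl)amino group, however (a 4.8-fold higher number from compound 3 to compound 4 (0.68 log units; beyond the scatter)), so ring-free groups on this carbonyl carbon still differ beyond the scatter.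

From the compounds shown here alone, whether one hydroxyl group alone, a shorter or longer hydroxyalkyl chain, an amine or a carboxylic acid would serve at this nitrogen stays open. Nothing available here accounts for these steps.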